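The source may report more compounds than this note shows. Statements on the series, on what has been measured and on what is new or still open speak of the compounds shown alone.

Measured in a functional assay on A549 cells (Homo sapiens) for antiproliferative activity, read by MTT assay, with a stated time of 72 h; a lower number here means a stronger inhibitor, a higher number a weaker inhibitor:
- compound 1 `NC1=C(C(=O)c2ccccc2)C(c2ccc(Br)cc2)N(CCCn2ccnc2)C1=O`: "not active" (no number reported)
- compound 2 `O=C(C1=C(Nc2ccc(Br)cc2)C(=O)N(CCCn2ccnc2)C1c1ccc(Br)cc1)c1ccccc1`: 22200 nM
- compound 3 `O=C(C1=C(Nc2ccc(Cl)cc2)C(=O)N(CCCn2ccnc2)C1c1ccc(Br)cc1)c1ccccc1`: 30000 nM

Compound 3 gives the highest of the two numbers; compound 2 lies nearest, and the step of a 1.4-fold higher number from compound 2 to compound 3 (0.13 log units; within the scatter) is within the scatter, so the two are not ranked against each other. Compound 4 `O=C(C1=C(Nc2ccc(OC(F)(F)F)cc2)C(=O)N(CCCn2ccnc2)C1c1ccc(Br)cc1)c1ccccc1` differs from compound 3 by trifluoromethoxy in place of chloro on an aromatic carbon. Going by the values given here, no measured step changes this position in the same way; the only measured step, a 1.4-fold higher number from compound 2 to compound 3 (0.13 log units; within the scatter), concerns a different exchange at the same place and was small. Without a closer precedent, the expected step of a 1.2-fold lower number from compound 3 to compound 4 (0.08 log units; within the scatter) is none beyond the scatter, in either direction. Compound 4 is therefore estimated at 25000 nM in this assay, with a range from 8000 nM to 80000 nM.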

Compound 4, half-maximal inhibitory concentration: 20800 nM
Compound 4: middle estimate off by 1.2-fold (0.08 log units), on the high side; the range from low to high includes it.
By their numbers in this assay, from the lowest: compounds 4, 2 and 3 (each within the scatter of the next).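

In this assay, trifluoromethoxy, a group with more heavy atoms than chloro or bromo and a hydrogen-bond acceptor, fits this place on the aromatic ring without a clear change: a 1.4-fold lower number from compound 3 to compound 4 (0.16 log units; within the scatter) and a 1.1-fold lower number from compound 2 to compound 4 (0.03 log units; within the scatter) both stay within the scatter. Chloro, bromo and trifluoromethoxy therefore cannot be ranked here, so this position shows no preference among these three groups. No other measurement bears on why the numbers stay so close.

On these data alone, whether an amine or a carboxylic acid at this place would move the number beyond the scatter remains open.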